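Hydroxyphenyl position swap in a pyridine-linked topoisomerase series

The source may hold more compounds than are shown below. What is called first, only, known or untested is meant among the compounds shown, and "the series" means these compounds.

Measured compounds:
compound 1, `Oc1ccc(-c2cc(-c3cccs3)cc(-c3cccc(O)c3)n2)cc1`, 1.1%
compound 2, `Oc1ccc(-c2cc(-c3cccs3)cc(-c3ccc(O)cc3)n2)cc1`, 0.9%
compound 3, `Oc1cccc(-c2cc(-c3cccnc3)cc(-c3ccccc3O)n2)c1`, 0%

Three compounds were tested in an assay on isolated protein for inhibition of DNA topoisomerase 1 (Homo sapiens), with a stated time of 30 min, tested at 20 uM; on this read-out higher numbers stand for a stronger effect at the one concentration tested and lower numbers for a weaker effect. Compound 1 gives 1.1%, compound 2 gives 0.9% and compound 3 gives 0% in this assay. All three numbers sit within the usual scatter of one another, so none of them can be set apart from the others.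

Compound 2 arises from compound 1 through (4-hydroxyphenyl in place of 3-hydroxyphenyl on an aromatic carbon). That change produced a number 0.2 percentage points lower from compound 1 to compound 2 (within the scatter).

Compound 4, `Oc1ccc(-c2cc(-c3cccnc3)cc(-c3ccccc3O)n2)cc1`, has not yet been measured. It arises from compound 3 through (4-hydroxyphenyl in place of 3-hydroxyphenyl on an aromatic carbon). This is the same kind of change as that from compound 1 to compound 2, though the surroundings differ: in compound 1 the place is meta to a 4-hydroxyphenyl group and meta to a thiophen-2-yl group, whereas in compound 3 it is meta to a 2-hydroxyphenyl group and meta to a pyridin-3-yl group. The difference between the two cores themselves is not broken down here.

Beside the earlier step, a step of a number 0.5 percentage points higher from compound 3 to compound 4 (within the scatter) is expected from compound 3 to compound 4 in this assay, because the earlier step of a number 0.2 percentage points lower from compound 1 to compound 2 (within the scatter) stayed within the scatter and compound 3 itself gives only 0%. Compound 4 is therefore estimated at 0.5%, expected to fall between 0% and 3%.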

Compound 4, a percentage reported as inhibition, at one concentration (the size of the read-out at that concentration, not a potency): 0%
The estimate for compound 4 lay 0.5 percentage points above the measured number; measured number inside the range.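

In this assay the swap of 3-hydroxyphenyl for 4-hydroxyphenyl gave no change at the digits printed from compound 3 to compound 4 (within the scatter), and set beside the earlier step on the other core, the result is the same within the scatter: the same change on two cores in this assay, a number 0.2 percentage points lower (within the scatter) from compound 1 to compound 2 and no change at the digits printed (within the scatter) from compound 3 to compound 4, 0.2 percentage points apart, within the scatter of two such steps. So far as these two pairs go, the change behaves alike on both cores, and on neither does it lift the read-out clear of the scatter. This does not show that the position of the hydroxyl is without consequence in general, since both steps start from very small numbers, compound 1 at 1.1% and compound 3 at 0%, and a single concentration gives no potency, so two steps of this kind cannot say how the change would behave on a core with a clear effect.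

The compounds shown leave open whether any member of this series gives a read-out that stands clear of the scatter in this assay. They also leave open what would follow if an amine or a carboxylic acid took the place of the hydroxyl, or if a longer chain took the place of the thiophen-2-yl or pyridin-3-yl group.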